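The compounds below may be only part of what the source reports. "The series", "measured", "known", "first", "only" and "open" are said of these compounds alone.

Measured compounds:
Compound 1, `CCn1c(SCC(=O)Nc2ccc(/C(C)=N/O)cc2)nnc1-c1ccc(OC)cc1`: 54%
Compound 2, `C=CCn1c(SCC(=O)Nc2ccc(/C(C)=N/O)cc2)nnc1-c1ccc(OC)c(OC)c1`: 53%

Both numbers come from a functional assay on the whole organism (strain albino) for inhibition, with Rattus norvegicus as the target, read by paw edema, with stated times of 30 min and 1 h, at a dose of 0.28 mmol/kg by the oral route; on this read-out higher numbers stand for more inhibition at the one dose given (going by the name of the read-out) and lower numbers for less inhibition. In this assay, within the data shown here, compound 2 gives 53%, while compound 1 gives 54%; the two readings lie within the usual scatter of each other, so the measurements do not tell the two compounds apart, and compound 2 stands level with its only neighbour rather than clearly under it. Compound 3, `C=CCn1c(SCC(=O)Nc2ccc(/C(C)=N/O)cc2)nnc1-c1ccc(OC)cc1`, has not yet been tested in this assay. It differs from compound 2 in a single place: hydrogen in place of methoxy on an aromatic carbon. Compound 3 thus carries the same 4-methoxyphenyl that compound 1 carries, and otherwise matches compound 2. Among the measured compounds shown here, with only two measured compounds, reading almost alike, and no measured step between them, there is no sign in these data that the groups on this ring move the inhibition. For compound 3 the expected step is a number 1 percentage points higher from compound 2 to compound 3 (within the scatter), small and in no particular direction beyond the scatter. Compound 3 is accordingly estimated at 54%, with a range from 42% to 66%.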

Compound 3, a percentage reported as inhibition, in the whole organism at one dose (the size of the read-out at that dose, not a potency): 54%
Beside the measured number, compound 3's estimate shows no gap at the digits printed, within the range that was stated.
By their numbers in this assay, from the lowest: compounds 2, 1 and 3 (each within the scatter of the next).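

Compounds 1 and 2 differ in two places at once, so neither change could be judged alone until compound 3 separated them. In this assay, going from 3,4-dimethoxyphenyl to 4-methoxyphenyl, with hydrogen in place of methoxy on the aromatic carbon, gives a number 1 percentage points higher from compound 2 to compound 3 (within the scatter) as the step, so the extra methoxy group shows no measurable effect on inhibition at this single dose. The other single change, vinyl in place of methyl on the saturated chain carbon bound to an aromatic nitrogen, gives no change at the digits printed from compound 1 to compound 3 (within the scatter) as its step, so this chain change cannot be told apart from no effect either, and no measurement given here offers an explanation for either result.

Going by these compounds, both changes are small, so it remains open whether a much different group on the aromatic ring, such as an amine or a carboxylic acid in place of methoxy, would shift the paw edema reading beyond the scatter. The same question stands for a longer chain on the aromatic nitrogen, and for hydrogen in place of the remaining methoxy group.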